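One chloro group fewer on compound 2

This account rests on a few compounds, and the source may have more. Where it says the series, first, only, none or still open, it means among the compounds named here.

In a functional assay on the whole organism with Mus musculus as the target (a higher number here means that more compound is needed for the effect, a lower number that less compound is needed), compound 2 `Cn1nc(-c2c(Cl)cccc2Cl)n(C)c1=S` gives > 100 mg/kg as a limit and not a number. Among the measured compounds shown here, compound 1 `Cn1nc(-c2ccc(Cl)cc2)nc1S` gives > 200 mg/kg as a limit too, so neither compound offers a number and no measured step sets a scale. Compound 3 `Cn1nc(-c2ccccc2Cl)n(C)c1=S` differs from compound 2 by hydrogen in place of chloro on an aromatic carbon and nothing else. In this assay the expected step of an at least 2.5-fold lower number from compound 2 to compound 3 (0.39 log units; beyond the scatter) runs towards less compound needed, with its size only loosely estimated. Compound 3 is estimated at 40 mg/kg with an expected range from 8 mg/kg to 150 mg/kg in this test.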

Compound 3, dose for half-maximal effect: 0.58 mg/kg
The estimate for compound 3 lay 69-fold (1.84 log units) above the measured number, outside the stated range (below it).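

With the other chloro group kept, this single position separates a limit from a measured number in this assay: hydrogen in place of chloro, ortho to a group of 8 heavy atoms, gives an at least 170-fold lower number from compound 2 to compound 3 (2.23 log units; beyond the scatter). Among the compounds shown here, this is the first step that sets a scale. Compound 2 carries a limit and not a number, so the step is a bound and not an exact size: the limit of > 100 mg/kg in this assay, at which 1 of the 3 values shown sits.

On these data alone, whether a methyl, a methoxy or an amine at this place would behave like hydrogen stays open. So does the part played by the remaining chloro group.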